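Aryl swaps at the benzylidene position of the shared core

The source may hold more compounds than are shown below. What is called first, only, known or untested is meant among the compounds shown, and "the series" means these compounds.

Measured so far:
compound 1, `O=C1C(=Cc2ccc(O)cc2)C(=O)N(c2ccc(Cl)cc2)N1c1ccc(Cl)cc1` — 34200 nM
compound 2, `O=C1C(=Cc2ccc(F)cc2)C(=O)N(c2ccc(Cl)cc2)N1c1ccc(Cl)cc1` — 35600 nM
compound 3, `COc1ccccc1C=C1C(=O)N(c2ccc(Cl)cc2)N(c2ccc(Cl)cc2)C1=O` — 30400 nM

All three numbers come from a functional assay on ECa-109 cells (Homo sapiens) for cytotoxicity, read by MTT assay, with a stated time of 72 h; on this read-out higher numbers stand for weaker inhibition and lower numbers for stronger inhibition. Compound 1 stands second highest of the three, with compound 2 nearest (a 1.0-fold higher number from compound 1 to compound 2 (0.02 log units; within the scatter)) and compound 3 furthest (a 1.1-fold lower number from compound 1 to compound 3 (0.05 log units; within the scatter)); the remaining pair also sits close (a 1.2-fold lower number from compound 2 to compound 3 (0.07 log units; within the scatter)). Nothing here separates the three compounds beyond the scatter.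

Compound 4, `O=C1C(=Cc2ccc(F)cc2F)C(=O)N(c2ccc(Cl)cc2)N1c1ccc(Cl)cc1`, has not yet been measured in this assay. It differs from compound 1 as follows: 2,4-difluorophenyl in place of 4-hydroxyphenyl on a double-bonded chain carbon bound to a double-bonded ring carbon.

Among the compounds with values here, the step that bears most directly on this change is the one from compound 1 to compound 2, where fluoro in place of hydroxy on an aromatic carbon gave a 1.0-fold higher number from compound 1 to compound 2 (0.02 log units; within the scatter). The step to the 2-methoxyphenyl of compound 3 likewise stayed inside the scatter (a 1.1-fold lower number from compound 1 to compound 3 (0.05 log units; within the scatter)). Within the data shown here, a second fluorine on the same ring has no measured precedent in this set, so the expectation rests on these flat steps alone. A step of a 1.0-fold lower number from compound 1 to compound 4 (0.00 log units; within the scatter) is therefore expected, not beyond the scatter in either direction.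

On that basis compound 4 is estimated at 34000 nM, with a range of 17000 nM to 70000 nM.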

Compound 4, half-maximal inhibitory concentration: 13100 nM
Beside the measured number, compound 4's estimate is 2.6-fold (0.41 log units) above it; measured number below the stated range.
By their numbers in this assay, from the lowest: compound 4; then compounds 3, 1 and 2 (each within the scatter of the next).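

Hydroxy, fluoro and methoxy aryl variants gave no separation at this position, on a double-bonded chain carbon bound to a double-bonded ring carbon, but in this assay the 2,4-difluorophenyl group moves the number beyond the scatter against all three earlier compounds (a 2.6-fold lower number from compound 1 to compound 4 (0.42 log units; beyond the scatter); a 2.3-fold lower number from compound 3 to compound 4 (0.37 log units; beyond the scatter); a 2.7-fold lower number from compound 2 to compound 4 (0.43 log units; beyond the scatter)), making compound 4 the most potent of the four. The closest comparison is with compound 2, since the pair differs only by one added fluoro on the ring (a 2.7-fold lower number from compound 2 to compound 4 (0.43 log units; beyond the scatter)), so the position responds to a one-atom change on the ring, although the modest step rests on this one pair and compound 2, which carries one fluoro yet stays level with compounds 1 and 3, goes against any reading that fluoro alone is enough. No available measurement accounts for this shift.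

The compounds shown leave open whether 2-fluorophenyl alone would give the same step, or whether the two fluoro groups are both required. They also leave open how chloro, trifluoromethyl or an amine on this ring would compare with the 2,4-difluorophenyl of compound 4.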